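The source may report more compounds than this note shows. Statements on the series, on what has been measured and on what is new or still open speak of the compounds shown alone.

In an ADME assay on the whole organism (Rattus norvegicus, strain Sprague-Dawley) for pharmacokinetics (a higher number here means that more of the compound sits outside the plasma, a lower number that more of the compound stays in the plasma), compound 1 (`Cc1cc(C(F)(F)F)ccc1-c1cc2cnn([C@@H](CC(C)C)c3ccc(C(=O)NCCC(=O)O)cc3)c2cc1C`) gives 2.67 L/kg and compound 2 (`Cc1cc(C(F)(F)F)ccc1-c1cc2cn([C@@H](CC(C)C)c3ccc(C(=O)NCCC(=O)O)cc3)nc2cc1C`) gives 2.94 L/kg as its number, the two lying within the scatter of each other. Compound 3 (`Cc1cc2c(cnn2[C@@H](CC(C)C)c2ccc(C(=O)NCCC(=O)O)cc2)cc1-c1ccc(C(F)(F)F)cc1Cl`) has not yet been measured. It differs from compound 1 by chloro in place of methyl on an aromatic carbon at one place: chloro in place of methyl on an aromatic carbon, ortho to a large group and meta to a trifluoromethyl group. For the measured compounds named here, no measured pair shows this change, so the expected 1.0-fold lower number from compound 1 to compound 3 (0.01 log units; within the scatter) stays within the scatter, in neither direction. In this assay the estimate for compound 3 is 2.6 L/kg with 1.5 L/kg and 4.2 L/kg as the expected ends of its range.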

Compound 3, volume of distribution at steady state: 3.32 L/kg
The estimate for compound 3 lay 1.3-fold (0.11 log units) below the measured number; low and high end bracket the measured number.
By their numbers in this assay, from the lowest: compounds 1, 2 and 3 (each within the scatter of the next).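

In this assay, chloro in place of methyl on this aromatic carbon, ortho to a large group and meta to a trifluoromethyl group, gives a 1.2-fold higher number from compound 1 to compound 3 (0.09 log units; within the scatter). For the compounds shown here, this is the first reading of a change at this place, since compound 1 and compound 2 both carry the 2-methyl-4-(trifluoromethyl)phenyl group, and here the swap stays inside the scatter. No available measurement offers an explanation for this result. Still open, going by these compounds, is how a methoxy group or a nitrile would read at this place, and whether chloro for methyl reads the same on the core of compound 2.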